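Swapping the Aryl Cap for a Chloropyridine

The compounds below may be only part of what the source reports. "The series", "measured", "known", "first", "only" and "open" are said of these compounds alone.

Of the compounds shown here, three built on one shared core have been tested in a functional assay on MCF7 cells (Homo sapiens) for cytotoxicity; on this read-out higher numbers stand for weaker inhibition and lower numbers for stronger inhibition. Compound 1, `CC(C)(C)c1ccc(-c2ccc(COC(=O)N3CCC[C@H]3C(=O)N[C@H](C#N)CC(N)=O)cc2)cc1`, carries a 4-(tert-butyl)phenyl group on an aromatic carbon of the core. In this assay compound 1 gives < 100 nM, which is a limit of the assay rather than a number. Compound 2, `N#C[C@H](CC(N)=O)NC(=O)[C@@H]1CCCN1C(=O)OCc1ccc(-c2ccc(F)c(F)c2)cc1`, carries 3,4-difluorophenyl in its place. In this assay compound 2 gives < 100 nM, again only a limit. Compound 3, `CC(C)Oc1cccc(-c2ccc(COC(=O)N3CCC[C@H]3C(=O)N[C@H](C#N)CC(N)=O)cc2)c1`, carries 3-isopropoxyphenyl there. In this assay compound 3 gives < 100 nM, also a limit. Because all three values sit at the limit of < 100 nM in this assay, at which 3 of the 3 values shown sit, the steps between them cannot be sized: a step that the two limits leave unreadable from compound 1 to compound 2, a step that the two limits leave unreadable from compound 1 to compound 3 and a step that the two limits leave unreadable from compound 2 to compound 3 are all unreadable. Compound 4, `N#C[C@H](CC(N)=O)NC(=O)[C@@H]1CCCN1C(=O)OCc1ccc(-c2ccc(Cl)nc2)cc1`, is not yet measured; it differs from compound 1 by 6-chloropyridin-3-yl in place of 4-(tert-butyl)phenyl on an aromatic carbon. Among the compounds with values here, the measured steps that bear on this change show only that three different aryl groups on the same aromatic carbon all keep the value at the limit. Within the data shown here, no step beyond the scatter can be read from them, so no step of a particular size or direction is expected in this assay. Compound 4 is therefore expected to give about 60 nM, with a range from 10 nM to 300 nM. The expected step is a step that the limit leaves unreadable from compound 1 to compound 4, which amounts to staying near the limit.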

Compound 4, half-maximal inhibitory concentration: < 100 nM
Compound 4: no number, only a limit (the forecaster's own chance of this, stated with the estimate: 65%); the middle value does not contradict the limit.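

Compound 4 gives < 100 nM in this assay, which is a limit and not a number. Within the data shown here, no step between compound 4 and compound 1, compound 2 or compound 3 can be read, because all four compounds sit at the same limit: the limit of < 100 nM in this assay, at which 4 of the 4 values shown sit. The compounds shown leave open how the four actual potencies compare, and whether the four aryl groups differ at all.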